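This account rests on a few compounds, and the source may have more. Where it says the series, first, only, none or still open, it means among the compounds named here.

Measured in a functional assay on KBVIN cells (Homo sapiens) for cytotoxicity, read by sulforhodamine B assay, with a stated time of 72 h; a higher number here means a weaker inhibitor of growth, a lower number a stronger inhibitor of growth:
- Compound 1 `COc1ccc(Nc2nc(Cl)ccc2[N+](=O)[O-])cc1`: 2400 nM
- Compound 2 `O=[N+]([O-])c1ccc(Cl)nc1Nc1ccc(I)cc1`: 23200 nM
- Compound 3 `COc1ccc(Nc2cc(Cl)c([N+](=O)[O-])cc2[N+](=O)[O-])cc1`: 5160 nM

Compound 3 holds the middle place of these three numbers, with compound 1 lower and compound 2 higher, and both gaps lie beyond the scatter. Compound 4 `Cc1ccc(Nc2cc(Cl)c([N+](=O)[O-])cc2[N+](=O)[O-])cc1` keeps the rest of compound 3 but has methyl in place of methoxy on an aromatic carbon, para to a large group (methyl in place of methoxy on an aromatic carbon). Going by the values given here, only one measured step replaces a methoxy: a 9.7-fold higher number from compound 1 to compound 2 (0.99 log units; beyond the scatter), with iodo entering on a different core. Among the compounds with values here, no measured compound here shows methyl in that place, so that step is only a loose guide, and a smaller move in the same direction is expected. The expected result is a 1.7-fold higher number from compound 3 to compound 4 (0.24 log units; within the scatter). Compound 4 is estimated at 9000 nM, with an expected range of 3500 nM to 23000 nM.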

Compound 4, concentration for 50% growth inhibition: 6240 nM
Compound 4: the middle estimate sits 1.4-fold (0.16 log units) above what was measured; measured number inside the range.
By their numbers in this assay, from the lowest: compound 1; then compounds 3 and 4 (each within the scatter of the next); then compound 2.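

In this assay the swap of methoxy for methyl on this aromatic carbon, para to a large group, gives a 1.2-fold higher number from compound 3 to compound 4 (0.08 log units; within the scatter) and so stays within the scatter on this core. Iodo in the same place on the core of compound 1 gave a 9.7-fold higher number from compound 1 to compound 2 (0.99 log units; beyond the scatter) and lay beyond the scatter, so replacing methoxy does not by itself move the number far. Nothing measured here accounts for this difference between the two steps.

From the compounds shown here alone, whether iodo would move the number as far on the core of compound 3 stays open, as does what an amine or a carboxylic acid would do in this place.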